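Capping the Hydroxy Group: From Compound 2 to Compound 3

This account rests on a few compounds, and the source may have more. Where it says the series, first, only, none or still open, it means among the compounds named here.

Compound 1: `COc1cc(Cl)cc(-c2nn(-c3cccc(NC(=O)c4cccc(C(F)(F)F)c4)c3)cc2-c2ccncc2)c1`, 37.9%
Compound 2: `O=C(Nc1cccc(-n2cc(-c3ccncc3)c(-c3cc(O)cc(Cl)c3)n2)c1)c1cc(C(F)(F)F)cc(C(F)(F)F)c1`, 15%

Of the compounds shown here, two have been measured in a functional assay on SF-295 cells (Homo sapiens) for inhibition, read by sulforhodamine B assay, with a stated time of 48 h, tested at 10 uM; on this read-out lower numbers stand for a stronger effect and higher numbers for a weaker effect at the one concentration tested. Compound 2 gives 15% and stands as the lowest of the two numbers, that is the stronger effect. Compound 1 gives 37.9%, a number higher than that of compound 2 by a margin beyond the usual scatter. These two compounds differ in more than one place, so their values can only be set side by side, not read as a single step.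

Compound 3 is `COc1cc(Cl)cc(-c2nn(-c3cccc(NC(=O)c4cc(C(F)(F)F)cc(C(F)(F)F)c4)c3)cc2-c2ccncc2)c1`. It differs from compound 2 in one place: methyl in place of hydrogen on an oxygen on an aromatic ring. For the measured compounds named here, no step between measured compounds isolates this change, so its size rests on expectation alone. Compound 1 also carries a methoxy group and gives 37.9%, but it differs from compound 2 elsewhere as well, so it offers only a hint. The step from compound 2 to compound 3 is expected to be a moderate rise in the read-out, toward a weaker effect, of about a number 12 percentage points higher from compound 2 to compound 3 (beyond the scatter). Compound 3 is therefore expected to give 27%, with a range from 12% to 45%.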

Compound 3, a percentage reported as activity, at one concentration (the size of the read-out at that concentration, not a potency): 42.1%
Beside the measured number, compound 3's estimate is 15.1 percentage points below it; measured number inside the range.
By their numbers in this assay, from the lowest: compound 2; then compounds 1 and 3 (each within the scatter of the next).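

In this assay, the change from hydroxy to methoxy on the aromatic ring can now be read on its own: a number 27.1 percentage points higher from compound 2 to compound 3 (beyond the scatter), a weaker effect at the one concentration tested, so the free hydroxy group matters at this position in this series. The second step isolates a different change, trifluoromethyl in place of hydrogen on an aromatic carbon, and with the methoxy group present it gives a number 4.2 percentage points higher from compound 1 to compound 3 (within the scatter), so that added trifluoromethyl makes no difference that can be told from the scatter. Nothing available explains why capping the oxygen with methyl weakens the effect.

The one step on the trifluoromethyl carries the methoxy group, so the compounds shown leave open whether the same exchange would also make no distinguishable difference with the hydroxy group in place. They also leave open how an amine or a longer ether such as ethoxy would compare with the hydroxy and methoxy groups at this position.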